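Swapping 3-methylphenyl for ethyl on the shared core

A few compounds are considered here, and "the series" means these few. Any claim that something is new, unique, unknown or untested is made for them only; others in the source may bear on it.

Compound 2 `Cc1cccc(Cn2cc(C(N)=O)c3c(N)ncnc32)c1` stands at the edge of what a functional assay on KB cells (Homo sapiens) for cytotoxicity (on this read-out lower numbers stand for stronger inhibition and higher numbers for weaker inhibition), can report: in this assay compound 2 gives > 100000 nM, which is a limit of the assay and not a number (the limit of > 100000 nM in this assay, at which 1 of the 2 values shown sits). In this assay compound 1 `NC(=O)c1cn(Cc2ccccc2)c2ncnc(N)c12` gives 75000 nM. Going by the values given here, the only measured step, an at least 1.3-fold higher number from compound 1 to compound 2 (0.12 log units; that floor lies within the scatter), concerns a methyl in place of hydrogen on an aromatic carbon. Compound 3 `CCCn1cc(C(N)=O)c2c(N)ncnc21` differs from compound 2 by ethyl in place of 3-methylphenyl on a saturated chain carbon bound to an aromatic nitrogen. Among the compounds with values here, no measured step covers this exchange, so no change beyond the scatter is expected. Compound 3 is estimated at 100000 nM, between 40000 nM and 300000 nM. This expectation means a step of a number no higher from compound 2 to compound 3 (the limit leaves the size open).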

Compound 3, half-maximal inhibitory concentration: 100000 nM
Estimate against measurement, compound 3: no gap at the digits printed; the range from low to high includes it.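

Ethyl in place of phenyl on a saturated chain carbon bound to an aromatic nitrogen gives a 1.3-fold higher number from compound 1 to compound 3 (0.12 log units; within the scatter). At this position, then, a small chain without a ring reads the same as the phenyl of compound 1. Ethyl in place of 3-methylphenyl on a saturated chain carbon bound to an aromatic nitrogen gives a number no higher from compound 2 to compound 3 (the limit leaves the size open). Compound 2 carries a limit of the assay and not a number, so the size of this step cannot be read: the limit of > 100000 nM in this assay, at which 1 of the 3 values shown sits.

As far as these compounds go, whether a longer chain, or an amine or a carboxylic acid on the chain, would move the number beyond the scatter stays open.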